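The source may hold more compounds than are shown below. What is called first, only, known or untested is meant among the compounds shown, and "the series" means these compounds.

Working notes on the series, with clearance followed in an ADME assay on the whole organism (Rattus norvegicus, strain Sprague-Dawley) for pharmacokinetics, using cassette dosing, at a dose of 0.5 mg/kg by the intravenous route (on this read-out higher numbers stand for fast clearance and lower numbers for slow clearance), as the only read-out. In this measurement compound 1 `O[C@]1(Cc2cc(-c3cn[nH]c3)on2)CC[C@@H](Cc2ccc(C(F)(F)F)cc2)CC1` gives 4 mL/min/kg as one of the two numbers available. The other comes from compound 2 `O=C(c1cc(-c2cn[nH]c2)on1)N1CCC(Cc2ccccc2)CC1` at 71.6 mL/min/kg on the same scale. For compound 3 `O=C(c1cc(-c2cn[nH]c2)on1)N1CCC(Cc2ccc(F)cc2)CC1` the entry reads "not determined" (no result reported) and so it holds no place on the clearance scale.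

Compound 4 `O=C(c1cc(-c2cn[nH]c2)on1)N1CCC(Cc2ccc(Cl)cc2)CC1` is the next amide to be read. The structural change is chloro in place of fluoro on an aromatic carbon with chloro in place of fluoro on an aromatic carbon, para to a large group.

For the measured compounds named here, no measured step is available to size this exchange, since compound 3 has no number. No step beyond the usual scatter is expected from it, and no direction is assigned. The working reference is therefore compound 2 at 71.6 mL/min/kg as the closest amide with a number. Compound 4 is estimated at 55 mL/min/kg with an expected range from 22 mL/min/kg to 110 mL/min/kg in this measurement.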

Compound 4, clearance: 29.2 mL/min/kg
Compound 4: the middle estimate sits 1.9-fold (0.27 log units) above what was measured; the range from low to high includes it.
By their numbers in this assay, from the lowest: compound 1; then compound 4; then compound 2.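

In this assay, adding a chloro group to the aromatic ring, para to a large group, gives a 2.5-fold lower number from compound 2 to compound 4 (0.39 log units; beyond the scatter). For the compounds shown here, this is the first sized change in the amide series, and it shows that clearance responds to substitution at this position, by a modest step beyond the usual scatter. As far as these compounds go, the exchange of fluoro for chloro itself cannot be read, as compound 3 has no number, so whether the two halogens differ at this position remains unknown.

Also open, from the compounds shown here alone, is whether a nitrile, a methoxy group or a carboxylic acid in the same place would lower clearance further, or reverse the step. The data in hand include no measurement that bears on the origin of this step.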